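This account rests on a few compounds, and the source may have more. Where it says the series, first, only, none or still open, it means among the compounds named here.

Compound 1 `N#Cc1nc2c(-c3nc4ccccc4[nH]3)c(N)n(CCN3CCCC3)c2nc1C#N` reaches in a functional assay on cells (Homo sapiens) for antiproliferative activity, read by MTT assay, with a stated time of 48 h (a higher number here means a weaker inhibitor, a lower number a stronger inhibitor), only a limit of the assay, > 50000 nM. Compound 2 `N#Cc1nc2c(-c3nc4ccccc4[nH]3)c(N)n(CCO)c2nc1C#N` likewise stops at a limit in this assay, > 50000 nM. Going by the values given here, the single measured step, a step that the two limits leave unreadable from compound 1 to compound 2, cannot be sized because of the limit of > 50000 nM in this assay, at which 2 of the 2 values shown sit. Compound 3 `N#Cc1nc2c(-c3nc4ccccc4[nH]3)c(N)n(CCCN3CCCCC3)c2nc1C#N` differs from compound 1 as (piperidin-1-yl)methyl in place of pyrrolidin-1-yl on a saturated chain carbon, two bonds along the chain from an aromatic nitrogen. The measured step touches the same place but a different change, and its unreadable size gives no direction for this one. Compound 3 is expected to show a step that the limit leaves unreadable from compound 1 to compound 3, most likely ending again at the limit. The estimate for compound 3 in this assay is 60000 nM, ranging from 15000 nM to 250000 nM.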

Compound 3, half-maximal inhibitory concentration: 6230 nM
The estimate for compound 3 lay 9.6-fold (0.98 log units) above the measured number; measured number below the stated range.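

In this assay, the chain on the aromatic nitrogen now gives a readable value: replacing pyrrolidin-1-yl with (piperidin-1-yl)methyl gives an at least 8.0-fold lower number from compound 1 to compound 3 (0.90 log units; beyond the scatter). Replacing hydroxy at the same place gives an at least 8.0-fold lower number from compound 2 to compound 3 (0.90 log units; beyond the scatter). Both steps are bounds, not exact sizes, since compound 1 and compound 2 each stand at a limit of the assay: the limit of > 50000 nM in this assay, at which 2 of the 3 values shown sit.

The change alters ring size and chain length together, so the compounds shown do not separate the two. A 3-(pyrrolidin-1-yl)propyl or 2-(piperidin-1-yl)ethyl group at this place would tell them apart.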